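The source may hold more compounds than are shown below. What is called first, only, known or untested is meant among the compounds shown, and "the series" means these compounds.

Measured in a functional assay on MCF7 cells (Homo sapiens) for inhibition, read by WST assay, with stated times of 72 h and 2 h; a lower number here means a stronger inhibitor, a higher number a weaker inhibitor:
compound 1 `OC(c1cccs1)c1cc2ccccc2nc1Cl`: 80600 nM
compound 2 `Cc1ccc(-c2cc(COC(c3cccs3)c3cc4ccccc4nc3Cl)on2)cc1`: "not active" (no number reported)

Compound 2 has no single number to stand on: in this assay compound 2 is recorded only as "not active" (no number reported). For the measured compounds named here, no measured step therefore starts from it, and the two compounds show only a number on one side and none on the other.

The next structure is compound 3 `Oc1ccc(-c2cc(COC(c3cccs3)c3cc4ccccc4nc3Cl)on2)cc1`. The change is hydroxy in place of methyl on an aromatic carbon, para to a large group.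

A modest step towards stronger inhibition is expected in this assay, though the outcome may again be no number at all. Going by the values given here, the only numerical anchor is compound 1 at 80600 nM, so the expectation stays in that weak range. For compound 3 the estimated half-maximal inhibitory concentration is 40000 nM, with an expected range from 10000 nM to 100000 nM.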

Compound 3, half-maximal inhibitory concentration: "not active" (no number reported)
Nothing numeric was reported for compound 3; there is nothing to compare the estimate with.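

Compound 3, like compound 2, is recorded only as "not active" in this assay, so no step can be read between them. No measurement here bears on a cause. The compounds shown leave open whether the 4-hydroxyphenyl group changes inhibition at all.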